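Amine for Hydroxyl on the Side Chain of Compound 3

A few compounds are considered here, and "the series" means these few. Any claim that something is new, unique, unknown or untested is made for them only; others in the source may bear on it.

The measured compounds:
compound 1, `CCCC(C)Nc1nc(N)nc2ccccc12`, 0.17 uM
compound 2, `CCCCNc1nc(N)nc2c(F)cccc12`, 0.3 uM
compound 3, `CCCCNc1nc(N)nc2cc(CO)ccc12`, 0.1 uM

All three were tested in an ADME assay on HEK293 cells for agonist activity at Toll-like receptor 8 (Homo sapiens), read by a luciferase reporter, with a stated time of 6 h; on this read-out higher numbers stand for an effect only at larger amounts of compound and lower numbers for an effect already at smaller amounts. Compound 3 shows the lowest of the three numbers. Its nearest neighbour is compound 1, whose value lies within the usual scatter of the value of compound 3, so the two cannot be told apart. The furthest is compound 2, whose value stands beyond the scatter from that of compound 3, so compound 3 acts at smaller amounts than compound 2. Going by the values given here, none of the three measured pairs differs in one place only, so no single-point step is available from the measured set.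

Compound 4, `CCCCNc1nc(N)nc2cc(CN(C)C)ccc12`, has not yet been measured. It differs from compound 3 in one place: dimethylamino in place of hydroxy on a saturated chain carbon bound to an aromatic carbon. The hydroxy group leaves and a dimethylamino group enters on a saturated chain carbon bound to an aromatic carbon; the hydrogen-bond donor is lost and one acceptor remains.

Among the compounds with values here, no measured step speaks to this kind of change here, so the expectation rests on the value of compound 3 alone. Compound 4 is expected to give a value close to that of compound 3, with a step of about a 1.5-fold higher number from compound 3 to compound 4 (0.18 log units; within the scatter), which is estimated to lie within the scatter in either direction. The estimate for compound 4 in this assay is 0.15 uM, with a range from 0.05 uM to 0.5 uM.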

Compound 4, minimum effective concentration: 0.04 uM
Compound 4: middle estimate off by 3.8-fold (0.57 log units), on the high side; the whole stated range lies above it.
By their numbers in this assay, from the lowest: compound 4; then compounds 3, 1 and 2 (each within the scatter of the next, the first and the last beyond it).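

In this assay, the place on the saturated chain carbon bound to an aromatic carbon proves open to change, and the exchange of hydroxy for dimethylamino moves the read-out toward smaller amounts (a 2.5-fold lower number from compound 3 to compound 4 (0.40 log units; beyond the scatter)). Going by these compounds alone, this is the first single-place comparison in the set, and although the step is modest, it lies beyond the scatter. It also shows that the hydrogen-bond donor of the hydroxy group is not needed at this place for an effect at smaller amounts, with the hydrogen-bond acceptor count unchanged and two more heavy atoms entering; nothing available explains why the number falls.

A single step cannot separate the effect of losing the hydroxy group from that of bringing in the amine, and a methoxy group or an unsubstituted amino group at the same place would be needed to tell these apart. Also open, from the compounds shown here alone, are how a carboxylic acid or a longer chain carrying the dimethylamino group would read here, and whether the same exchange holds with the side chains of compound 1 or the fluorine of compound 2.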